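The compounds below may be only part of what the source reports. "The series", "measured", "known", "first", "only" and "open" are said of these compounds alone.

Measured compounds:
Compound 1 `COc1cc(C)cc2c1C(=O)C=C(c1c(C)cc3c(c1OC)C(=O)C(Nc1ccc4ccccc4c1)=CC3=O)C2=O` gives 240 nM in a functional assay on Ehrlich cells (Mus musculus) for cytotoxicity, read by MTT assay, with a stated time of 24 h; on this read-out higher numbers stand for weaker inhibition and lower numbers for stronger inhibition.
Compound 2 `COc1cc(C)cc2c1C(=O)C=C(c1c(C)cc3c(c1OC)C(=O)C(NCc1ccccc1)=CC3=O)C2=O` gives 1410 nM in this assay.

Of the two numbers shown, compound 2 stands highest, and its nearest neighbour is compound 1, from which it is separated by a 5.9-fold higher number from compound 1 to compound 2 (0.77 log units; beyond the scatter). Compound 3 `COc1cc(C)cc2c1C(=O)C=C(c1c(C)cc3c(c1OC)C(=O)C(NC(C)=O)=CC3=O)C2=O` has not yet been measured in this assay. The change that leads to it is acetyl in place of benzyl on an amine nitrogen.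

Among the compounds with values here, only one measured step bears on this change: a 5.9-fold higher number from compound 1 to compound 2 (0.77 log units; beyond the scatter), where a smaller aromatic group on the amine nitrogen gave a weaker inhibitor. The step to compound 3 takes the aromatic ring away altogether, so a further weakening of similar or somewhat larger size is expected, giving a 2.5-fold higher number from compound 2 to compound 3 (0.39 log units; beyond the scatter). Compound 3 is therefore estimated at 3500 nM in this assay, with a likely range from 1000 nM to 12000 nM.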

Compound 3, half-maximal inhibitory concentration: 60 nM
For compound 3 the middle estimate is 58-fold (1.77 log units) above the measured one; the measured number lies below the stated range.
By their numbers in this assay, from the lowest: compound 3; then compound 1; then compound 2.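

The acetyl group on this amine nitrogen reverses the direction suggested by the first two compounds. In this assay replacing benzyl with acetyl gives a 24-fold lower number from compound 2 to compound 3 (1.37 log units; beyond the scatter) and replacing naphthalen-2-yl with acetyl gives a 4.0-fold lower number from compound 1 to compound 3 (0.60 log units; beyond the scatter) so an aromatic ring on this nitrogen is not needed for strong inhibition, and compound 3 has the lowest number of the three. No measurement shown explains why this change has such a large effect.

The compounds shown leave open whether other groups joined through a carbonyl, such as propionyl or benzoyl, match acetyl at this nitrogen. They also leave open how the unsubstituted amine compares, and whether adding a methyl group in place of the amide hydrogen changes the result.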